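One more fluoro on a compound known only by limits

The source may hold more compounds than are shown below. What is called first, only, known or untested is meant among the compounds shown, and "the series" means these compounds.

Compound 1 `COc1ccc(/C=C/C(=O)Oc2ccc(C(C)=O)cc2)cc1` – > 3270000 nM (a limit)
Compound 2 `CC(=O)c1ccc(OC(=O)/C=C/c2cccc(F)c2)cc1` – > 3100000 nM (a limit)
Compound 3 `CC(=O)c1ccc(OC(=O)/C=C/c2ccc(F)cc2)cc1` – > 3310000 nM (a limit)

All three readings come from an ADME assay on HepG2 2.2.15 cells (Homo sapiens) for cytotoxicity, read by MTT assay (on this read-out lower numbers stand for higher toxicity in this test and higher numbers for lower toxicity in this test), and none of them is a true number. On these data alone, compound 3, the starting point here, has only its limit of > 3310000 nM to show, so its real place on the scale stays open.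

The next compound is compound 4 `CC(=O)c1ccc(OC(=O)/C=C/c2ccc(F)c(F)c2)cc1` and its change is small: fluoro in place of hydrogen on an aromatic carbon (fluoro in place of hydrogen on an aromatic carbon, ortho to the fluoro group already there).

Among the compounds with values here, two measured steps bear on this change. One is a step that the two limits leave unreadable from compound 1 to compound 3 with fluoro in place of methoxy, and the other is a step that the two limits leave unreadable from compound 2 to compound 3 with 4-fluorophenyl in place of 3-fluorophenyl. Neither has a size that can be read, so they offer no measured effect to carry over. Still, neither fluoro compound gave a number, and that makes a step beyond the scatter in this assay unlikely. The expected outcome is an at least 1.0-fold lower number from compound 3 to compound 4 (0.01 log units; that floor lies within the scatter) in size, most likely with another limit as the reading. For compound 4 the estimated value is 3200000 nM (expected range 1500000 nM to 6000000 nM).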

Compound 4, half-maximal cytotoxic concentration: > 2590000 nM
Compound 4 ended at the assay's limit; the forecaster's own chance of this, stated with the estimate: 85%; the middle value is on the limit's open side.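

In this assay compound 4 gives > 2590000 nM, which is a limit and not a true number. Compound 2 and compound 3 are also known only by limits, and the steps from each of them to compound 4 cannot be read. The true place of these compounds on the scale, and whether the added fluoro shifts it, stays open.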